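Swapping the aryl substituent on a fused bicyclic core

A few compounds are considered here, and "the series" means these few. Any claim that something is new, unique, unknown or untested is made for them only; others in the source may bear on it.

Measured compounds in an ADME assay on the whole organism (Mus musculus, strain Swiss Webster) for pharmacokinetics, read by LC-MS, at a dose of 50 mg/kg by the oral route; on this read-out higher numbers stand for higher exposure at the dose given and lower numbers for lower exposure:
compound 1, `O=C(Nc1ccc(F)c(-c2nc3ncc(-c4cc(F)ccc4F)cc3[nH]2)c1)N1CCCC1`: 5620 ng.h/mL
compound 2, `O=C(Nc1ccc(F)c(-c2nc3ncc(-c4cncc(F)c4)cc3[nH]2)c1)N1CCCC1`: 1560 ng.h/mL
compound 3, `O=C(Nc1ccc(F)c(-c2nc3ncc(C(F)(F)F)cc3[nH]2)c1)N1CCCC1`: 489 ng.h/mL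

Compound 1 stands highest of the three numbers in this assay. Its nearest neighbour is compound 2, reached by a 3.6-fold lower number from compound 1 to compound 2 (0.56 log units; beyond the scatter), and the furthest is compound 3, reached by an 11-fold lower number from compound 1 to compound 3 (1.06 log units; beyond the scatter). Compound 2 and compound 3 are themselves separated by a 3.2-fold lower number from compound 2 to compound 3 (0.50 log units; beyond the scatter), so each departure from the 2,5-difluorophenyl of compound 1 has so far gone downward and beyond the scatter.

Going by the values given here, the unmeasured compound 4, `O=C(Nc1ccc(F)c(-c2nc3ncc(-c4ccc(O)cc4)cc3[nH]2)c1)N1CCCC1`, differs from compound 1 in one place: 4-hydroxyphenyl in place of 2,5-difluorophenyl on an aromatic carbon The group that enters brings a hydrogen-bond donor and acceptor that neither compound 1, compound 2 nor compound 3 carries at this position, so no measured step covers that feature directly. Among the compounds with values here, the steps that bear on it are those leaving the same 2,5-difluorophenyl, from compound 1 to compound 2 and from compound 1 to compound 3, both lowering. On that basis a lowering step of modest size is expected, a 4.7-fold lower number from compound 1 to compound 4 (0.67 log units; beyond the scatter), though the absence of any measured phenol makes the width of the range large. Compound 4 is therefore estimated at 1200 ng.h/mL in this assay, with a range from 300 ng.h/mL to 4000 ng.h/mL.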

Compound 4, area under the concentration-time curve: 137 ng.h/mL
The estimate for compound 4 lay 8.8-fold (0.94 log units) above the measured number; the measured number lies below the stated range.
By their numbers in this assay, from the lowest: compound 4; then compound 3; then compound 2; then compound 1.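

The 4-hydroxyphenyl group gives the lowest number of the four in this assay, with a 41-fold lower number from compound 1 to compound 4 (1.61 log units; beyond the scatter). A carbon-only aromatic ring at this position therefore does not by itself hold the number up, since the 4-hydroxyphenyl group keeps that ring type yet falls below the ring-free trifluoromethyl group, with a 3.6-fold lower number from compound 3 to compound 4 (0.55 log units; beyond the scatter), and further below the 5-fluoropyridin-3-yl group, with an 11-fold lower number from compound 2 to compound 4 (1.06 log units; beyond the scatter). Nothing in the material at hand explains this fall, so the result stands as an observation only.

The compounds shown do not separate the effect of the hydroxyl from that of losing the two fluorines, a question that a plain phenyl, a 4-fluorophenyl or a 4-methoxyphenyl at the same position would address. Exposure is also the only read-out here, so it remains open which step between the oral dose and the area under the curve accounts for the low number, and whether an amine or a carboxylic acid on this ring would fall as far.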